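The source may hold more compounds than are shown below. What is called first, only, known or untested is meant among the compounds shown, and "the series" means these compounds.

Compound 3 `CC1(C)CC(NC(=O)Nc2ccccc2)c2cc(Cl)ccc2O1` is the reference point here. In a functional assay on U-373MG ATCC cells (Homo sapiens) for inhibition, read by MTT assay, with a stated time of 72 h (on this read-out higher numbers stand for weaker inhibition and lower numbers for stronger inhibition), compound 3 gives 68000 nM, which is the highest of the two plain numbers shown, though its companion sits very close. Compound 1 `CC1(C)CC(NC(=O)NCc2ccccc2)c2cc(Cl)ccc2O1` gives 66000 nM in this assay, and the step of a 1.0-fold higher number from compound 1 to compound 3 (0.01 log units; within the scatter) is a swap of phenyl in place of benzyl on an amide-type nitrogen that changes essentially nothing. Compound 2 `CCOC(=O)NC1CC(C)(C)Oc2ccc(Cl)cc21` is reported only as a limit in this assay, > 100000 nM, so it marks the limit of > 100000 nM in this assay, at which 1 of the 3 values shown sits, rather than a measured number. The steps of an at least 1.5-fold higher number from compound 1 to compound 2 (0.18 log units; that floor lies within the scatter) and an at least 1.4-fold lower number from compound 2 to compound 3 (0.16 log units; that floor lies within the scatter) both have floors that sit inside the usual scatter.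

Compound 4 `CC1(C)CC(NC(=O)Nc2ccc(Cl)cc2)c2cc(Cl)ccc2O1` carries the change (chloro in place of hydrogen on an aromatic carbon). Among the measured compounds shown here, none of the measured steps touches this ring position: they alter the group on the carbonyl carbon or exchange phenyl for benzyl, and each of them stays within the scatter. For the measured compounds named here, with no measured step that speaks to a chloro on the anilino ring, and every neighbouring change so flat, compound 4 is expected to stay close to compound 3, with the step of a 1.1-fold lower number from compound 3 to compound 4 (0.05 log units; within the scatter) not clearly beyond the scatter. Compound 4 is therefore estimated at 60000 nM, between 25000 nM and 150000 nM.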

Compound 4, half-maximal inhibitory concentration: 19000 nM
Estimate against measurement, compound 4: 3.2-fold (0.50 log units) above; measured number outside the range, below it.
By their numbers in this assay, from the lowest: compound 4; then compounds 1 and 3 (each within the scatter of the next). At a limit, above all of these: compound 2.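

Among the compounds shown here, a chloro on an aromatic carbon, para to a large group, is the only single change here that moves the number in this assay clearly beyond the scatter: a 3.6-fold lower number from compound 3 to compound 4 (0.55 log units; beyond the scatter). This part of the molecule is therefore not as flat as the swap of phenyl for benzyl suggested, and the comparison with the benzyl compound points the same way, with 4-chlorophenyl in place of benzyl giving a 3.5-fold lower number from compound 1 to compound 4 (0.54 log units; beyond the scatter). With ethoxy on the carbonyl carbon as the starting point, the step reads an at least 5.2-fold lower number from compound 2 to compound 4 (0.72 log units; beyond the scatter), and that figure is a floor rather than a measured size: the limit of > 100000 nM in this assay, at which 1 of the 4 values shown sits.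

With only one substituent at this place, the compounds shown cannot tell whether the gain is particular to chloro or whether a fluoro, a methyl or a methoxy group in the same place would give a similar step. Going by these compounds, it also remains open whether a chloro added to the phenyl ring of the benzyl group in compound 1 would lower the number in the same way, and why the chloro has this effect at all.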